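The source may report more compounds than this note shows. Statements on the series, on what has been measured and on what is new or still open speak of the compounds shown alone.

Compound 2 `Cc1cc(C#N)cc(C)c1Oc1ccnc(S(=O)(=O)CC(=O)Nc2cccc(F)c2)n1` carries a 3-fluorophenyl on the amide-type nitrogen of the shared core. Among the compounds with values here, in an ADME assay on MT4 cells (Homo sapiens) for cytotoxicity, read by MTT assay, with a stated time of 4 days (a higher number here means that more compound is tolerated, a lower number that less compound is tolerated), compound 2 gives 25900 nM, the second highest of the three numbers known. Compound 1 `Cc1cc(C#N)cc(C)c1Oc1ccnc(S(=O)(=O)CC(=O)Nc2ccccc2)n1`, with a plain phenyl in that position, gives 29300 nM in this assay, and the step of a 1.1-fold lower number from compound 1 to compound 2 (0.05 log units; within the scatter) lies within the scatter. Compound 3 `Cc1cc(C#N)cc(C)c1Oc1ccnc(S(=O)(=O)CC(=O)Nc2ccc(Cl)c(Cl)c2)n1` gives 11700 nM in this assay, and the steps of a 2.5-fold lower number from compound 1 to compound 3 (0.40 log units; beyond the scatter) and a 2.2-fold lower number from compound 2 to compound 3 (0.35 log units; beyond the scatter) are modest lowerings beyond the scatter.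

Compound 4 `Cc1cc(C#N)cc(C)c1Oc1ccnc(S(=O)(=O)CC(=O)Nc2cccc([N+](=O)[O-])c2)n1` differs from compound 2 in one place: nitro in place of fluoro on an aromatic carbon. Within the data shown here, no measured step exchanges fluoro for nitro, so only the general picture bears on it: the fluoro in compound 2 brought no change beyond the scatter, while the 3,4-dichlorophenyl of compound 3 lowered the number modestly. The nitro change is therefore expected to move compound 4 little, with a slight lean toward a lower number, as a 1.2-fold lower number from compound 2 to compound 4 (0.09 log units; within the scatter). Compound 4 is estimated at 21000 nM in this assay, with a range from 10000 nM to 44000 nM.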

Compound 4, half-maximal cytotoxic concentration: 23600 nM
For compound 4 the middle estimate is 1.1-fold (0.05 log units) below the measured one; the measured number falls inside the stated range.
By their numbers in this assay, from the lowest: compounds 3, 4, 2 and 1 (each within the scatter of the next, the first and the last beyond it).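

In this assay, the 3-nitrophenyl of compound 4 shows that nitro, with its three heavy atoms and two hydrogen-bond acceptors, can stand on this aromatic carbon, meta to a large group, with no step beyond the scatter: a 1.1-fold lower number from compound 2 to compound 4 (0.04 log units; within the scatter) and a 1.2-fold lower number from compound 1 to compound 4 (0.09 log units; within the scatter) are both small. Set against the dichlorinated compound, a 2.0-fold higher number from compound 3 to compound 4 (0.30 log units; within the scatter) also stays within the scatter, so compound 4 lies within the scatter of all three earlier compounds, although compound 1 and compound 3 are separated by more than the scatter. Nothing shown gives a reason for these steps.

Still open, as far as these compounds go, is whether an amine or a carboxylic acid on the same aromatic carbon would also leave the number within the scatter. Also open, from the compounds shown here alone, is whether a single chlorine, as in 3-chlorophenyl, would give a step like that of the 3,4-dichlorophenyl in compound 3.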